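The source may report more compounds than this note shows. Statements on the series, on what has been measured and on what is new or still open speak of the compounds shown alone.

Of the compounds shown here, three of a shared core have been tested so far. Compound 1 `CC(C)=CCC1Cc2c(OCc3ccccc3)cc(=O)n(CCCO)c2CC1(C)C` gives -0.3% in a functional assay on PANC-1 cells (Homo sapiens) for inhibition, read by MTT assay, with a stated time of 24 h, tested at 10 uM; a lower number here means less inhibition, a higher number more inhibition at the concentration tested (going by the name of the read-out). Compound 2 `CC(C)=CCC1Cc2c(OCCCOc3ccc(Cl)cc3)cc(=O)n(CCCO)c2CC1(C)C` gives 22.7%, and compound 3 `CC(C)=CCC/C(C)=C/CC1Cc2c(OCc3ccccc3)cc(=O)n(CCCO)c2CC1(C)C` gives 46.5%. On these numbers compound 3 stands highest of the three: its gap to compound 2 and its gap to compound 1 are both beyond the scatter, and the rise a number 46.8 percentage points higher from compound 1 to compound 3 (beyond the scatter) comes from adding 3-methylbut-2-en-1-yl to the side chain.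

Compound 4 `COc1ccc(NC(=O)Oc2cc(=O)n(CCCO)c3c2CC(C/C=C(\C)CCC=C(C)C)C(C)(C)C3)cc1` keeps that longer side chain and instead alters the group on the ring oxygen: (4-methoxyphenyl)carbamoyl in place of benzyl on an oxygen on an aromatic ring. Within the data shown here, the only measured step that touches this same oxygen is a number 23 percentage points higher from compound 1 to compound 2 (beyond the scatter), where a different group on the oxygen raised the read-out by a modest amount. That step does not involve the group entering here, so it only suggests that changes at this oxygen have so far not lowered the read-out.

Taking compound 3 as the starting point, a small rise or no change beyond the scatter is expected, with the estimated step being a number 5.5 percentage points higher from compound 3 to compound 4 (within the scatter). Compound 4 is therefore estimated at 52%, within a range from 30% to 72%.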

Compound 4, a percentage reported as inhibition, at one concentration (the size of the read-out at that concentration, not a potency): 64.1%
Compound 4: middle estimate off by 12.1 percentage points, on the low side, within the range that was stated.
By their numbers in this assay, from the lowest: compound 1; then compound 2; then compound 3; then compound 4.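

In this assay, among these compounds, the change from benzyl to (4-methoxyphenyl)carbamoyl on the oxygen on an aromatic ring gives a number 17.6 percentage points higher from compound 3 to compound 4 (beyond the scatter), so this oxygen can still move the read-out upward when the longer side chain is present, whereas the earlier step here, a number 23 percentage points higher from compound 1 to compound 2 (beyond the scatter), was seen only with the shorter side chain. The rise also comes without losing the six-membered aromatic ring, as both groups carry one, and the entering group adds a carbamoyl link with one hydrogen-bond donor and two hydrogen-bond acceptors, where benzyl has none. Nothing available explains why this swap raises the read-out.

The compounds shown leave open whether the rise belongs to the carbamoyl link or to the methoxy group on its ring, a question that a plain phenylcarbamoyl group, with hydrogen in place of the methoxy, could help to settle. They also leave open whether (4-methoxyphenyl)carbamoyl would raise the read-out in the same way on the shorter side chain of compound 1.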